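Bromo for iodo on the shared core: a weak-cytotoxicity series

The compounds below may be only part of what the source reports. "The series", "measured", "known", "first", "only" and "open" are said of these compounds alone.

Compound 1 `OCC(CO)OCn1cc(I)c2c(NO)ncnc21` carries iodo on the five-membered aromatic ring of the shared core. In an ADME assay on HFF cells (Homo sapiens) for cytotoxicity (on this read-out higher numbers stand for weaker inhibition and lower numbers for stronger inhibition), compound 1 gives > 100000 nM, a limit of the assay and not a number. Compound 2 `OCC(CO)OCn1ccc2c(NO)ncnc21` differs by hydrogen in place of iodo on an aromatic carbon. In this assay compound 2 gives > 100000 nM, again a limit. Compound 3 `OC[C@H]1O[C@@H](n2cc(Br)c3c(NO)ncnc32)[C@H](O)[C@@H]1O` carries bromo on the same core with a different group on the ring nitrogen. In this assay compound 3 gives > 100000 nM, also a limit. Compound 1 therefore cannot be placed relative to the others, since every value shown sits at the limit of > 100000 nM in this assay, at which 3 of the 3 values shown sit. Within the data shown here, the only single-point step, a step that the two limits leave unreadable from compound 1 to compound 2, is unreadable because both of its ends sit at the limit of > 100000 nM in this assay, at which 3 of the 3 values shown sit.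

Compound 4 `OCC(CO)OCn1cc(Br)c2c(NO)ncnc21` is reached from compound 1 by bromo in place of iodo on an aromatic carbon. Among the measured compounds shown here, no measured step sets bromo against iodo on this core; compound 3 shows bromo only with another group on the ring nitrogen and only as a limit. The step that the limit leaves unreadable from compound 1 to compound 4 is therefore expected to show no change beyond the scatter, with the value most likely reported once more as a limit. Compound 4 is expected to give 200000 nM in this assay, with a range from 100000 nM to 1000000 nM.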

Compound 4, half-maximal inhibitory concentration: > 100000 nM
Compound 4: no number, only a limit; the forecaster's own chance of this, stated with the estimate: 90%; the middle value does not contradict the limit.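

No step from compound 1 or compound 2 to compound 4 can be read, since each has a limit at both ends and not a number: the limit of > 100000 nM in this assay, at which 4 of the 4 values shown sit.

The compounds shown leave open whether iodo, bromo or hydrogen on the shared core makes any difference in this assay beyond that limit.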